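Working notes: the butyl step to compound 3

The source may report more compounds than this note shows. Statements on the series, on what has been measured and on what is new or still open speak of the compounds shown alone.

In a physicochemical assay for lipophilicity (on this read-out higher numbers stand for higher lipophilicity and lower numbers for lower lipophilicity), compound 1 (`CCCCCCn1c(N)c(N)c(=O)[nH]c1=O`) gives 1.01 and compound 2 (`CCCCCCCCn1c(=O)[nH]c(=O)c2[nH]c(O)nc21`) gives 1.1 so the two values stand within the scatter of each other. Compound 3 (`CCCCCCCCCCCCn1c(=O)[nH]c(=O)c2[nH]c(O)nc21`) differs from compound 2 by butyl in place of hydrogen on a saturated chain carbon, eight bonds along the chain from an aromatic nitrogen. For the measured compounds named here, no measured step between compounds differing in one place is available, so the expectation rests on the structural change alone. An upward step beyond the scatter is expected in this assay and is estimated as a number 1.90 log units higher from compound 2 to compound 3 (beyond the scatter) on that basis. Compound 3 is expected at 3 with an estimated range from 2.2 to 3.8 as the working figure.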

Compound 3, partition coefficient: 2.9
The estimate for compound 3 lay 0.10 log units above the measured number, within the range that was stated.
By their numbers in this assay, from the lowest: compounds 1 and 2 (each within the scatter of the next); then compound 3.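

Butyl in place of hydrogen on a saturated chain carbon, eight bonds along the chain from an aromatic nitrogen, gives the first one-place comparison in the series. In this assay the step is a number 1.80 log units higher from compound 2 to compound 3 (beyond the scatter) and counts as large, whereas compound 1 and compound 2 differ in more than one place and offered no such reading. Nothing measured on hand bears on the reason for this step.

On these data alone, a single step fixes no trend, and how a longer chain would read on the shared core stays open. Equally open, as far as these compounds go, is what an amine or a carboxylic acid would give in place of the butyl.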